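A few compounds are considered here, and "the series" means these few. Any claim that something is new, unique, unknown or untested is made for them only; others in the source may bear on it.

Measured so far in an assay on isolated protein with metabotropic glutamate receptor 5 (Rattus norvegicus) as the target; a lower number here means that less compound is needed, a higher number that more compound is needed for the effect:
compound 1, `O=C(Nc1cc(-c2ccccc2)nn1-c1ccccc1)c1ccc(F)c(F)c1`, 20 nM
compound 2, `O=C(Nc1cc(-c2ccccc2)nn1-c1ccccc1)c1ccccc1`, 300 nM
compound 3, `O=C(Nc1cc(-c2ccccc2)nn1-c1ccccc1)c1ccccc1F`, 100 nM

Compound 3 holds the second highest of these three numbers: it sits nearest compound 2, reached by a 3.0-fold lower number from compound 2 to compound 3 (0.48 log units; beyond the scatter), and furthest from compound 1, reached by a 5.0-fold higher number from compound 1 to compound 3 (0.70 log units; beyond the scatter). Compound 4, `Cc1cccc(C(=O)Nc2cc(-c3ccccc3)nn2-c2ccccc2)c1`, differs from compound 3 by 3-methylphenyl in place of 2-fluorophenyl on a carbonyl carbon. Within the data shown here, two measured steps bear on this: the fluoro taken away was worth a 3.0-fold lower number from compound 2 to compound 3 (0.48 log units; beyond the scatter), while the larger loss of fluorine was a 15-fold higher number from compound 1 to compound 2 (1.18 log units; beyond the scatter). Nothing measured speaks to a methyl group. Compound 4 is therefore expected to give a modestly higher number than compound 3, estimated at a 2.5-fold higher number from compound 3 to compound 4 (0.40 log units; beyond the scatter). In this assay compound 4 is expected near 250 nM, between 80 nM and 800 nM.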

Compound 4, half-maximal effective concentration: 100 nM
Estimate against measurement, compound 4: 2.5-fold (0.40 log units) above; the measured number falls inside the stated range.
By their numbers in this assay, from the lowest: compound 1; then compounds 3 and 4 (each within the scatter of the next); then compound 2.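

At this position on the carbonyl carbon, a fluoro group is not required for the improvement over plain phenyl: 3-methylphenyl in place of 2-fluorophenyl gives (no change at the digits printed from compound 3 to compound 4 (within the scatter)), and methyl in place of hydrogen gives (a 3.0-fold lower number from compound 2 to compound 4 (0.48 log units; beyond the scatter)). Even so, the single methyl does not close the gap to the 3,4-difluorophenyl group (a 5.0-fold higher number from compound 1 to compound 4 (0.70 log units; beyond the scatter)). No evidence at hand explains this result.

Going by these compounds, whether a chloro, methoxy or amine substituent on this ring would behave like methyl remains open. So does whether a second methyl group would reach the level of compound 1.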